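The source may hold more compounds than are shown below. What is called first, only, known or untested is meant among the compounds shown, and "the series" means these compounds.

Compound 1 `CC(C)(C)c1ccc(CNCCCNS(=O)(=O)c2cc(C(F)(F)F)cc(C(F)(F)F)c2)cc1` and compound 2 `COc1cccc(CNCCCNS(=O)(=O)c2cc(C(F)(F)F)cc(C(F)(F)F)c2)c1` share a chain of three saturated carbons between a sulfonamide nitrogen and an amine nitrogen; in a functional assay on BE(2)-C cells (Homo sapiens) for inhibition, read by MTT assay, with a stated time of 72 h (on this read-out higher numbers stand for weaker inhibition of growth and lower numbers for stronger inhibition of growth), compound 1 gives 2500 nM and compound 2 gives 4500 nM, with a 1.8-fold higher number from compound 1 to compound 2 (0.26 log units; within the scatter). Compound 3 `CN(CCCNS(=O)(=O)c1cc(C(F)(F)F)cc(C(F)(F)F)c1)Cc1ccccc1` gives 28000 nM in this assay, the highest of the three numbers, after a 6.2-fold higher number from compound 2 to compound 3 (0.79 log units; beyond the scatter). Compound 4 `O=S(=O)(NCCCNCc1ccc(Br)cc1)c1cc(C(F)(F)F)cc(C(F)(F)F)c1` is to be measured in this assay. Its change from compound 3 is (4-bromobenzyl)amino in place of benzyl(methyl)amino on a saturated chain carbon, three bonds along the chain from a sulfonamide nitrogen. The step from compound 2 to compound 3 bears on it most directly, since it removed the same hydrogen-bond donor that now returns, so a step back toward the numbers of compound 1 and compound 2 is expected, namely an 8.0-fold lower number from compound 3 to compound 4 (0.90 log units; beyond the scatter). For compound 4 the estimate is 3500 nM, between 1200 nM and 9000 nM.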

Compound 4, concentration for 50% growth inhibition: 2700 nM
Estimate against measurement, compound 4: 1.3-fold (0.11 log units) above; measured number inside the range.
By their numbers in this assay, from the lowest: compounds 1, 4 and 2 (each within the scatter of the next); then compound 3.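

The step to (4-bromobenzyl)amino brings a 10-fold lower number from compound 3 to compound 4 (1.02 log units; beyond the scatter) in this assay, though it changes the methyl on nitrogen and the bromo together. With the hydrogen-bond donor present, the aryl substituent shifts the number little: there is a 1.7-fold lower number from compound 2 to compound 4 (0.22 log units; within the scatter) and a 1.1-fold higher number from compound 1 to compound 4 (0.03 log units; within the scatter), both small steps among these three compounds. No measurement shown gives a cause for these results.

From the compounds shown here alone, whether the methyl or the bromo carries the large step stays open, and a plain benzylamino group would help separate them. Going by these compounds, how an amide in place of the amine would behave also remains open.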